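The compounds below may be only part of what the source reports. "The series", "measured", "known", "first", "only" and "open" are said of these compounds alone.

Measured so far in a physicochemical assay for acid dissociation:
- compound 1 `CO[C@@H]1[C@@H](OC(=O)c2ccc(C)[nH]2)[C@@H](O)[C@H](Oc2ccc3c(N4CCN(c5ccccn5)CC4)cc(=O)oc3c2C)OC1(C)C`: 5.5
- compound 2 `CO[C@@H]1[C@@H](OC(=O)c2ccc(C)[nH]2)[C@@H](O)[C@H](Oc2ccc3c(N4CCNC(C)C4)cc(=O)oc3c2C)OC1(C)C`: 8.3

Of the two numbers, the higher belongs to compound 2 at 8.3, and the lower to compound 1 at 5.5. Compound 3 `CO[C@@H]1[C@@H](OC(=O)c2ccc(C)[nH]2)[C@@H](O)[C@H](Oc2ccc3c(N4CC(C)NC(C)C4)cc(=O)oc3c2C)OC1(C)C` differs from compound 2 by methyl in place of hydrogen on a saturated ring carbon, which turns 3-methylpiperazin-1-yl into 3,5-dimethylpiperazin-1-yl.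

Within the data shown here, only one measured step bears on this change: a number 2.80 log units higher from compound 1 to compound 2 (beyond the scatter). That large step exchanged 4-(pyridin-2-yl)piperazin-1-yl for 3-methylpiperazin-1-yl on an aromatic carbon, so it replaced a whole group, whereas the present change adds a methyl to a ring carbon. Among the measured compounds shown here, it is therefore a weak guide, and no measured step isolates an added methyl. In this assay, a small rise that may stay within the scatter is expected, so the estimate is anchored on compound 2 at 8.3. The estimated change is a number 0.10 log units higher from compound 2 to compound 3 (within the scatter). The expected value for compound 3 is 8.4, within an estimated range from 8 to 8.8.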

Compound 3, acid dissociation constant: 8
The estimate for compound 3 lay 0.40 log units above the measured number; measured number inside the range.
By their numbers in this assay, from the lowest: compound 1; then compounds 3 and 2 (each within the scatter of the next).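

In this assay, among these compounds, the methyl in place of hydrogen on a saturated ring carbon, next to the ring nitrogen, is the first change confined to a single added carbon, and it stays within the scatter (a number 0.30 log units lower from compound 2 to compound 3 (within the scatter)), so 3-methylpiperazin-1-yl and 3,5-dimethylpiperazin-1-yl cannot be told apart here. The large gap to compound 1 now appears with a second group, 3,5-dimethylpiperazin-1-yl in place of 4-(pyridin-2-yl)piperazin-1-yl (a number 2.50 log units higher from compound 1 to compound 3 (beyond the scatter)), and so does not rest on compound 2 alone. No measurement accompanying these numbers accounts for either step.

Open, as far as these compounds go, is whether an ethyl or a longer chain, or a hydroxymethyl, on the same ring carbon would also stay within the scatter of compound 2. Also open, from the compounds shown here alone, is how much of the large gap belongs to the pyridin-2-yl group itself, a question on which an unsubstituted piperazin-1-yl, or a 4-methylpiperazin-1-yl, would bear directly.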